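Swapping iodo for methoxy: an estimate for compound 4

This account rests on a few compounds, and the source may have more. Where it says the series, first, only, none or still open, it means among the compounds named here.

Measured in a functional assay on MDA-MB-231 cells (Homo sapiens) for antiproliferative activity, read by MTT assay, with a stated time of 72 h; on this read-out higher numbers stand for weaker inhibition and lower numbers for stronger inhibition:
Compound 1 `O=C(CCc1cccc2c1B(O)OC2)NC1CCCCC1`: > 100000 nM (a limit, not a number)
Compound 2 `O=C(CCc1cccc2c1B(O)OC2)Nc1ccc(F)cc1`: 440 nM
Compound 3 `O=C(CCc1cccc2c1B(O)OC2)Nc1ccc(I)cc1`: 33000 nM

Only compound 2 and compound 3 have true numbers, and compound 3 holds the higher of the two at 33000 nM, so it is the weaker inhibitor of that pair. Compound 4 `COc1ccc(NC(=O)CCc2cccc3c2B(O)OC3)cc1` has methoxy in place of iodo on an aromatic carbon, para to a large group: methoxy in place of iodo on an aromatic carbon.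

The most relevant measured step is at this same place, with iodo in place of fluoro: a 75-fold higher number from compound 2 to compound 3 (1.88 log units; beyond the scatter). That step is large. Two steps from the cyclohexyl amide show how much the choice of group matters: an at least 220-fold lower number from compound 1 to compound 2 (2.35 log units; beyond the scatter) and an at least 3.0-fold lower number from compound 1 to compound 3 (0.48 log units; beyond the scatter). For the measured compounds named here, no methoxy compound has been measured yet. Since compound 2 shows that this place can reach 440 nM, a clearly lower number than for compound 3 is expected, though probably not the whole gap. The expected change is an 11-fold lower number from compound 3 to compound 4 (1.04 log units; beyond the scatter). For compound 4 the estimated value is 3000 nM, with an expected range of 400 nM to 25000 nM.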

Compound 4, half-maximal inhibitory concentration: 850 nM
Compound 4: middle estimate off by 3.5-fold (0.55 log units), on the high side, and the stated range covers the measured number.
By their numbers in this assay, from the lowest: compounds 2 and 4 (each within the scatter of the next); then compound 3. At a limit, above all of these: compound 1.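

In this assay the swap of iodo for methoxy gives a 39-fold lower number from compound 3 to compound 4 (1.59 log units; beyond the scatter) and so shows that the high number of compound 3 is not fixed by the shared core or the aromatic amide. Methoxy in place of fluoro gives a 1.9-fold higher number from compound 2 to compound 4 (0.29 log units; within the scatter) and these two compounds cannot be told apart, so this place on the ring accepts both a group of one heavy atom and a group of two. Among the three aromatic amides, iodo is now the one that stands apart, with compound 2 and compound 4 sitting together.

As far as these compounds go, whether chloro, bromo, an amine or a carboxylic acid at this place would stay with compound 2 and compound 4 or move towards compound 3 remains open. The data shown give no reason why iodo behaves differently.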